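This account rests on a few compounds, and the source may have more. Where it says the series, first, only, none or still open, it means among the compounds named here.

Two compounds of a shared core carrying a dithiocarbamate side chain have been measured so far. Compound 1 `Nc1ccccc1NC(=O)c1ccc(CSC(=S)N2CCc3ccccc32)cc1` and compound 2 `Nc1ccccc1NC(=O)c1ccc(CSC(=S)N2CCN(c3ccc(F)cc3)CC2)cc1` differ in the amine that bears the thiocarbonyl. In a functional assay on MGC-803 cells (Homo sapiens) for antiproliferative activity, read by CCK-8 assay, with a stated time of 72 h, tested at 8 uM (a higher number here means a stronger effect of the compound at the concentration tested, a lower number a weaker effect), compound 1 gives 87%, while compound 2 gives 48.7%, the lower of the two values, and the gap between them lies beyond the usual scatter of this assay.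

Compound 3 `Nc1ccccc1NC(=O)c1ccc(CSC(=S)N2CCN(Cc3cccnc3)CC2)cc1` has not yet been measured. It keeps the six-membered non-aromatic ring with two nitrogen atoms of compound 2 but changes the group on its amine nitrogen: (pyridin-3-yl)methyl in place of 4-fluorophenyl on an amine nitrogen in a ring. The group that leaves and the group that enters each count seven heavy atoms, and the entering one brings a single hydrogen-bond acceptor.

Within the data shown here, no pair of measured compounds shows this particular change, so there is no measured step to lean on. Compound 3 is therefore expected to stay near compound 2, with a step of a number 1.3 percentage points higher from compound 2 to compound 3 (within the scatter) that is not expected to exceed the scatter in either direction. The estimate for compound 3 in this assay is 50%, with a range from 30% to 70%.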

Compound 3, a percentage reported as inhibition, at one concentration (the size of the read-out at that concentration, not a potency): 64.6%
Compound 3: middle estimate off by 14.6 percentage points, on the low side; low and high end bracket the measured number.
By their numbers in this assay, from the lowest: compound 2; then compound 3; then compound 1.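

At the amine nitrogen of the six-membered non-aromatic ring with two nitrogen atoms, the group carried is not indifferent: in this assay, placing (pyridin-3-yl)methyl where 4-fluorophenyl stood gives a number 15.9 percentage points higher from compound 2 to compound 3 (beyond the scatter), a modest step. Among these compounds, this position therefore responds to a change of group even when the heavy-atom count stays the same, which the earlier compounds, differing in the whole amine, could not show. The change alters several things at once, since the carbon-only aromatic ring gives way to a ring with one hetero atom, a hydrogen-bond acceptor enters, and the ring is now attached through a methyl carbon, and no measurement here bears on which of these accounts for the step.

The compounds shown leave open whether the step follows the pyridine nitrogen or the added carbon link, a question that a benzyl group or a directly attached pyridin-3-yl group on the same nitrogen would separate. They also leave open what a small methyl group, or a hydrogen alone, on that nitrogen would do to the read-out.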